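Side-chain configuration in a hydroxyalkylamino amide series

The compounds below may be only part of what the source reports. "The series", "measured", "known", "first", "only" and "open" are said of these compounds alone.

Measured so far in a functional assay (Pituitary gland cell) with Rattus norvegicus as the target; on this read-out lower numbers stand for an effect already at smaller amounts and higher numbers for an effect only at larger amounts of compound:
compound 1 `CC(C)(CC(=O)N[C@@H]1CCc2ccccc2N(Cc2ccc(-c3ccccc3-c3nn[nH]n3)cc2)C1=O)NCCO` gives 30 nM
compound 2 `C[C@@H](O)CNC(C)(C)C(=O)N[C@@H]1CCc2ccccc2N(Cc2ccc(-c3ccccc3-c3nn[nH]n3)cc2)C1=O` gives 300 nM
compound 3 `C[C@@H](O)CCNC(C)(C)C(=O)N[C@@H]1CCc2ccccc2N(Cc2ccc(-c3ccccc3-c3nn[nH]n3)cc2)C1=O` gives 100 nM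

Compound 3 stands second highest of the three numbers in this assay. Its nearest neighbour is reached by a 3.0-fold lower number from compound 2 to compound 3 (0.48 log units; beyond the scatter); the wider gap is a 3.3-fold higher number from compound 1 to compound 3 (0.52 log units; beyond the scatter). Both are modest steps, beyond the scatter.

Compound 4 `C[C@H](O)CCNC(C)(C)C(=O)N[C@@H]1CCc2ccccc2N(Cc2ccc(-c3ccccc3-c3nn[nH]n3)cc2)C1=O` is the next compound. Against compound 3 the change is: the two compounds have the same atoms and bonds and differ only in configuration as drawn: 1 of 2 stereo elements differ; a stereocentre at a saturated chain carbon is drawn R in compound 3 and S in compound 4. Within the data shown here, none of the measured steps alters configuration alone; each of them changes the make-up of the hydroxyalkyl chain, so they do not bear directly on this step. Among the measured compounds shown here, with no precedent, the expected step is no change at the digits printed from compound 3 to compound 4 (within the scatter), that is, nothing beyond the scatter. The estimate for compound 4 in this assay is 100 nM, with a range of 35 nM to 300 nM.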

Compound 4, concentration for half-maximal effect: 50 nM
The estimate for compound 4 lay 2.0-fold (0.30 log units) above the measured number; the measured number falls inside the stated range.
By their numbers in this assay, from the lowest: compounds 1, 4 and 3 (each within the scatter of the next, the first and the last beyond it); then compound 2.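

Inverting the saturated chain carbon from R to S gives a 2.0-fold lower number from compound 3 to compound 4 (0.30 log units; within the scatter) in this assay, the first read on configuration alone in this series, and it isolates that change: the fact that compounds 3 and 4 differ only in the configuration as drawn. The S chain still separates from the 1-hydroxyethyl chain of compound 2, with a 6.0-fold lower number from compound 2 to compound 4 (0.78 log units; beyond the scatter), while against the chain of compound 1 there is a 1.7-fold higher number from compound 1 to compound 4 (0.22 log units; within the scatter).

From the compounds shown here alone, whether configuration matters on the 1-hydroxyethyl chain of compound 2 remains open. So does the outcome of a methyl ether or a carboxylic acid in place of the hydroxyl group, or of a longer chain.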